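Ring-nitrogen substituent steps toward compound 4

This account rests on a few compounds, and the source may have more. Where it says the series, first, only, none or still open, it means among the compounds named here.

Measured so far:
compound 1 `CCN1C(=O)CSC1c1cccc(C(=O)NCCCCc2ccccc2)c1`: 6%
compound 2 `COc1cc(F)ccc1N1C(=O)CSC1c1cccc(C(=O)NCCCCc2ccccc2)c1`: 81%
compound 3 `CC(F)(F)c1cccc(N2C(=O)CSC2c2cccc(C(=O)NCCCCc3ccccc3)c2)c1`: 23%

In a functional assay on HOS cells (Homo sapiens) for inhibition, read by CCK-8 assay, with a stated time of 72 h, tested at 1 uM (on this read-out higher numbers stand for more inhibition at the one concentration tested (going by the name of the read-out) and lower numbers for less inhibition), compound 3 gives 23% and stands second highest of the three numbers: a number 17 percentage points higher from compound 1 to compound 3 (beyond the scatter), while a number 58 percentage points lower from compound 2 to compound 3 (beyond the scatter). Compound 4 `COc1c(F)cccc1N1C(=O)CSC1c1cccc(C(=O)NCCCCc2ccccc2)c1` is the next step; its change from compound 3 is a group of 9 heavy atoms (7 carbon, 1 oxygen, 1 fluorine; one six-membered aromatic ring of carbon only) in place of a group of 10 heavy atoms (8 carbon, 2 fluorine; one six-membered aromatic ring of carbon only), on an amide-type nitrogen in a ring. The step that bears most on it is the reverse-type change a number 58 percentage points lower from compound 2 to compound 3 (beyond the scatter), which was large; a number 75 percentage points higher from compound 1 to compound 2 (beyond the scatter) likewise shows the 4-fluoro-2-methoxyphenyl compound far above the ethyl one. Compound 4 carries 3-fluoro-2-methoxyphenyl rather than 4-fluoro-2-methoxyphenyl, so a return to the level of compound 2 is not assured, but a large rise is expected: a number 42 percentage points higher from compound 3 to compound 4 (beyond the scatter). Compound 4 is thus estimated at 65%, within 35% to 90%.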

Compound 4, a percentage reported as inhibition, at one concentration (the size of the read-out at that concentration, not a potency): 9%
For compound 4 the middle estimate is 56 percentage points above the measured one; the measured number lies below the stated range.
By their numbers in this assay, from the lowest: compounds 1 and 4 (each within the scatter of the next); then compound 3; then compound 2.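

Across the fluoro-methoxyphenyl pair at this ring nitrogen, the 3-fluoro-2-methoxyphenyl group in place of the 4-fluoro-2-methoxyphenyl group gives a large drop in this assay (a number 72 percentage points lower from compound 2 to compound 4 (beyond the scatter)), so the high reading of compound 2 does not extend to its isomer. The 3-fluoro-2-methoxyphenyl group also reads modestly under the group of compound 3 (a number 14 percentage points lower from compound 3 to compound 4 (beyond the scatter)) and stays level with ethyl (a number 3 percentage points higher from compound 1 to compound 4 (within the scatter)). Nothing available accounts for this gap between the two isomers.

The compounds shown leave open how 2-methoxyphenyl without fluorine would read at this nitrogen. They also leave open how a phenyl ring bearing an amine or a carboxylic acid would read there.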